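The source may hold more compounds than are shown below. What is called first, only, known or untested is meant among the compounds shown, and "the series" means these compounds.

Measured so far in a functional assay on the whole organism for antagonist activity, with Mus musculus as the target (on this read-out lower numbers stand for an effect already at smaller amounts and higher numbers for an effect only at larger amounts of compound), are three compounds:
compound 1 `CCC(=O)N(c1ccc(Cl)cc1)C1CCCC1N(C)C` with 0.2 mg/kg as its value
compound 2 `CCC(=O)N(c1ccc(OC)cc1)C1CCCC1N(C)C` with 20 mg/kg; 20 mg/kg (2 entries) as its value
compound 3 `CCC(=O)N(c1cccc(C)c1)C1CCCC1N(C)C` with 1 mg/kg; 1 mg/kg (2 entries) as its value

Compound 1 has the lowest number of the three, and compound 2 has the highest. Two further entries for compound 1 in this assay gave no single number, so its standing rests on one value.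

The next compound is compound 4 `CCC(=O)N(c1ccc(Cl)c(C)c1)C1CCCC1N(C)C`, which has not yet been measured. It differs from compound 1 by one change, (methyl in place of hydrogen on an aromatic carbon), with methyl in place of hydrogen on an aromatic carbon, ortho to a chloro group and meta to a large group.

Among the measured compounds shown here, no measured pair in this set isolates that change, so the expectation rests on indirect evidence. Compound 3 also carries a methyl group but has no chloro group, and its value of 1 mg/kg; 1 mg/kg (2 entries) is lower than that of compound 2, which has 20 mg/kg; 20 mg/kg (2 entries) as its value. Methyl is therefore not expected to cost much, and a small upward step in this assay seems likely, perhaps barely beyond the usual scatter. The estimated change is a 1.5-fold higher number from compound 1 to compound 4 (0.18 log units; within the scatter) in this read-out. For compound 4 the expected value is 0.3 mg/kg with an estimated range from 0.08 mg/kg to 1.2 mg/kg until the measurement is known.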

Compound 4, dose for half-maximal effect: 2 mg/kg
Beside the measured number, compound 4's estimate is 6.7-fold (0.82 log units) below it; measured number outside the range, above it.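

The methyl group proves far from neutral at this position. In this assay, among the compounds shown here, placing it on the aromatic carbon ortho to a chloro group and meta to a large group gives a 10-fold higher number from compound 1 to compound 4 (1.00 log units; beyond the scatter), the first direct reading of this change, which the earlier compounds, with no pair differing in one place, could not supply. This step rests on a single number for compound 1 0.2 mg/kg and shows only that this one added carbon is enough to move the read-out beyond the usual scatter, while the data shown offer no measurement that would explain the shift.

On these data alone, what remains open is whether the rise belongs to methyl in particular or to any group on this carbon, a question that a fluoro group, a hydroxyl group or an amine at the same place would help to settle. As far as these compounds go, it is equally open whether an ethyl group or a longer chain there would carry the number further in the same direction, or whether the same methyl would matter as much with a group other than chloro on the neighbouring carbon of the shared core.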